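This account rests on a few compounds, and the source may have more. Where it says the series, first, only, none or still open, it means among the compounds named here.

Compound 1 `COC(=O)CCNC1=CS(=O)(=O)O[C@@]12[C@@H](CO[Si](C)(C)C(C)(C)C)O[C@@H](n1cc(C)c(=O)n(C)c1=O)[C@@H]2O[Si](C)(C)C(C)(C)C` gives > 250000 nM in a functional assay on MT4 cells (Homo sapiens) (a higher number here means that more compound is tolerated, a lower number that less compound is tolerated), which is a limit of the assay and not a number. Compound 2 `Cc1cn([C@@H]2O[C@H](CO[Si](C)(C)C(C)(C)C)[C@@]3(OS(=O)(=O)C=C3NCC(=O)OCc3ccccc3)[C@H]2O[Si](C)(C)C(C)(C)C)c(=O)n(C)c1=O` gives 250000 nM in this assay. Compound 3 `COC(=O)NC1=CS(=O)(=O)O[C@@]12[C@@H](CO[Si](C)(C)C(C)(C)C)O[C@@H](n1cc(C)c(=O)n(C)c1=O)[C@@H]2O[Si](C)(C)C(C)(C)C` gives 29900 nM in this assay.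

Among the two numbers that are not limits, compound 3 stands lowest, so it is the compound of which the cells tolerate least. Its nearest neighbour is compound 2, and the change between them is an 8.4-fold lower number from compound 2 to compound 3 (0.92 log units; beyond the scatter); likewise an at least 8.3-fold lower number from compound 1 to compound 3 (0.92 log units; beyond the scatter), although the limit of compound 1 leaves that size open.

Compound 4 `Cc1cn([C@@H]2O[C@H](CO[Si](C)(C)C(C)(C)C)[C@@]3(OS(=O)(=O)C=C3NC(=O)NC(=O)c3ccccc3)[C@H]2O[Si](C)(C)C(C)(C)C)c(=O)n(C)c1=O` has not yet been measured in this assay. The change is benzamido in place of methoxy on a carbonyl carbon. Both measured steps that end at compound 3 replaced a larger group on the amine nitrogen by the small methoxycarbonyl and gave a lower number, whereas here a larger group again enters, though on the carbonyl carbon rather than on the nitrogen. Within the data shown here, no measured step touches that very place, so the expectation is only loosely founded. The number for compound 4 in this assay is expected to rise, partly because compound 2 with its aromatic ring gives 250000 nM, by about a 2.7-fold higher number from compound 3 to compound 4 (0.43 log units; beyond the scatter). Compound 4 is thus estimated at 80000 nM, within a range from 20000 nM to 300000 nM.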

Compound 4, half-maximal cytotoxic concentration: 3330 nM
The estimate for compound 4 lay 24-fold (1.38 log units) above the measured number; the measured number lies below the stated range.
By their numbers in this assay, from the lowest: compound 4; then compound 3; then compound 2.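

In this assay, the carbonyl carbon on the amine nitrogen turns out to be a sensitive place: benzamido in place of methoxy gives a 9.0-fold lower number from compound 3 to compound 4 (0.95 log units; beyond the scatter), so cells tolerate less of compound 4. The earlier steps shown here all ended at the small methoxycarbonyl, yet the much larger benzoylcarbamoyl gives a 75-fold lower number from compound 2 to compound 4 (1.88 log units; beyond the scatter), so a small group on that nitrogen is not needed for a low number, and an aromatic ring in that group does not by itself keep the number high, as compound 2 and compound 4 both carry one. The step of an at least 75-fold lower number from compound 1 to compound 4 (1.87 log units; beyond the scatter) keeps its size open, since the value of compound 1 is a limit of the assay and not a number: the limit of > 250000 nM in this assay, at which 1 of the 4 values shown sits.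

The compounds shown do not separate the benzene ring from the added amide nitrogen, so a plain amino group or an acetamido group on that carbonyl carbon would be needed to tell the two apart. Whether the same change would lower the number on a different core also remains open, as all of these compounds share one.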